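This account rests on a few compounds, and the source may have more. Where it says the series, first, only, none or still open, it means among the compounds named here.

Compound 1 `Cc1ccccc1-c1nn(-c2ccc(F)cc2F)cc1CNCCN1CCN(C)CC1` serves as the reference point of this set. In an ADME assay on Huh-7 cells (Homo sapiens) for cytotoxicity (a lower number here means that less compound is tolerated, a higher number that more compound is tolerated), compound 1 gives only a limit of the assay, > 20000 nM, and not a number. Compound 2 `CN1CCN(CCNCc2cn(-c3ccc(F)cc3F)nc2-c2ccc(Cl)cc2)CC1` carries the change 4-chlorophenyl in place of 2-methylphenyl on an aromatic carbon relative to compound 1. In this assay compound 2 gives 19000 nM, which amounts to an at least 1.0-fold lower number from compound 1 to compound 2 (0.02 log units; that floor lies within the scatter). Compound 3 `Cc1ccccc1-c1nn(-c2ccc([N+](=O)[O-])cc2)cc1CNCCN1CCN(C)CC1` differs from compound 1 in its core by 4-nitrophenyl in place of 2,4-difluorophenyl on an aromatic nitrogen. In this assay compound 3 also gives only a limit of the assay, > 20000 nM. The step that the two limits leave unreadable from compound 1 to compound 3 therefore cannot be sized, because the limit of > 20000 nM in this assay, at which 2 of the 3 values shown sit, leaves both compounds at the same limit.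

Compound 4 `CN1CCN(CCNCc2cn(-c3ccc([N+](=O)[O-])cc3)nc2-c2ccc(Cl)cc2)CC1` has not yet been measured in this assay. It stands to compound 3 as compound 2 stands to compound 1, through (4-chlorophenyl in place of 2-methylphenyl on an aromatic carbon); this is the same kind of change, though the place differs in that the ring atom two ring bonds away bears a 4-nitrophenyl group (9 heavy atoms) rather than a 2,4-difluorophenyl group (8 heavy atoms). Compound 4 is expected to show a step of a number no higher from compound 3 to compound 4 (the limit leaves the size open) because an at least 1.0-fold lower number from compound 1 to compound 2 (0.02 log units; that floor lies within the scatter) stayed within the scatter. Compound 4 is thus estimated at 20000 nM, between 10000 nM and 40000 nM.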

Compound 4, half-maximal cytotoxic concentration: 5000 nM
Compound 4: the middle estimate sits 4.0-fold (0.60 log units) above what was measured; measured number outside the range, below it.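

In this assay, 4-chlorophenyl in place of 2-methylphenyl on the core carrying the 4-nitrophenyl group gives an at least 4.0-fold lower number from compound 3 to compound 4 (0.60 log units; beyond the scatter), and 4-nitrophenyl in place of 2,4-difluorophenyl, with the 4-chlorophenyl group kept, gives a 3.8-fold lower number from compound 2 to compound 4 (0.58 log units; beyond the scatter). The change thus carries a lower number beyond the scatter on the second core, but this does not show that it has a larger effect there than on the core of compound 1: the same change on two cores in this assay, an at least 1.0-fold lower number (0.02 log units; that floor lies within the scatter) from compound 1 to compound 2 and an at least 4.0-fold lower number (0.60 log units; beyond the scatter) from compound 3 to compound 4; the limit leaves it open whether they differ The true size of the step on the core of compound 1 cannot be read, and neither can the step between the two compounds with 2-methylphenyl, because their values are limits and not numbers: the limit of > 20000 nM in this assay, at which 2 of the 4 values shown sit.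

The compounds shown leave open whether a 4-fluorophenyl or 4-methylphenyl group on the same aromatic carbon would go with the same lower number on either core. They also leave open whether the step would persist with a piperidine or a longer chain in place of the methylpiperazine side chain.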